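The compounds below may be only part of what the source reports. "The series", "measured", "known", "first", "only" and "open" are said of these compounds alone.

Of the compounds shown here, three of a shared core have been measured in an assay on NIH3T3 cells with Urotensin-2 receptor (Homo sapiens) as the target; on this read-out higher numbers stand for an effect only at larger amounts of compound and lower numbers for an effect already at smaller amounts. Compound 1 `Cc1ccsc1C(=O)OC(CCN(C)C)c1ccc(Cl)cc1` gives 2510 nM in this assay, the highest of the three numbers; compound 2 `CN(C)CCC(OC(=O)c1ccc(C(F)(F)F)cc1)c1ccc(Cl)cc1` gives 1740 nM, a gap from compound 1 that stays within the usual scatter, while compound 3 `CN(C)CCC(OC(=O)c1ccc(-c2ccccc2)cc1)c1ccc(Cl)cc1` gives 525 nM, well separated from compound 1. Within the data shown here, the one step seen so far, a 3.3-fold lower number from compound 2 to compound 3 (0.52 log units; beyond the scatter), swaps a group on the ring of the ester and yields a modest gain.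

Compound 4 `Cc1cc(Br)ccc1C(=O)OC(CCN(C)C)c1ccc(Cl)cc1` differs from compound 1 by 4-bromo-2-methylphenyl in place of 3-methylthiophen-2-yl on a carbonyl carbon. Among the measured compounds shown here, no measured step replaces the whole ring on the carbonyl carbon, so the change from compound 1 to compound 4 is only loosely informed by the gain seen from compound 2 to compound 3, where a bulkier group on that ring helped. A small move toward lower numbers is therefore expected, but the step of a 1.7-fold lower number from compound 1 to compound 4 (0.22 log units; within the scatter) is estimated to stay close to the scatter. Compound 4 is expected to give about 1500 nM in this assay, within a range from 500 nM to 4500 nM.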

Compound 4, half-maximal effective concentration: 1070 nM
Compound 4: middle estimate off by 1.4-fold (0.15 log units), on the high side; the range from low to high includes it.
By their numbers in this assay, from the lowest: compound 3; then compounds 4, 2 and 1 (each within the scatter of the next, the first and the last beyond it).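

In this assay the earlier step only swapped a group on a ring, whereas here the whole ring on the carbonyl carbon is exchanged and the result is a 2.3-fold lower number from compound 1 to compound 4 (0.37 log units; beyond the scatter) and so a modest gain. This position therefore accepts 4-bromo-2-methylphenyl, a six-membered ring of carbon only, in place of a five-membered ring holding sulfur, and the sulfur is not required for a number of this size. No measurement at hand explains this step.

The ring and the bromine change together in this single step, which leaves open how much of the gain belongs to each. Also open, on these data alone, is how the number would respond to an amine or a carboxylic acid in place of the bromine on this ring.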